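Changing the Group on Sulfur: Compound 3

The compounds below may be only part of what the source reports. "The series", "measured", "known", "first", "only" and "open" are said of these compounds alone.

Measured so far in a functional assay on A-375 cells (Homo sapiens) for inhibition, read by CCK-8 assay, with a stated time of 72 h, tested at 2 uM; a lower number here means less inhibition of growth, a higher number more inhibition of growth at the concentration tested:
- compound 1 `Nc1ccccc1NC(=O)/C=C/c1ccc(CSc2cccc(F)c2)cc1`: 6.75%
- compound 2 `Nc1ccccc1NC(=O)/C=C/c1ccc(CSc2ccc(C(F)(F)F)cn2)cc1`: 10.3%

Only these two compounds have numbers, and they lie within the usual scatter of each other, so compound 2 cannot be ranked apart from compound 1. The next compound is compound 3 `Cc1ccc(SCc2ccc(/C=C/C(=O)Nc3ccccc3N)cc2)cc1`. Its structural change is 4-methylphenyl in place of 5-(trifluoromethyl)pyridin-2-yl on a sulfur. In short, it has 4-methylphenyl in place of 5-(trifluoromethyl)pyridin-2-yl on a sulfur. Going by the values given here, one measured step bears on this, another exchange of the group on that sulfur. Among the compounds with values here, with a number 3.6 percentage points higher from compound 1 to compound 2 (within the scatter) as the only such exchange, no step beyond the scatter is expected in this assay, and no direction can be favoured. Within the data shown here, this is thin evidence, since 4-methylphenyl itself has no measurement yet. The estimated change is a number 1.3 percentage points lower from compound 2 to compound 3 (within the scatter). Compound 3 is estimated at 9%, with an expected range from 2% to 20%.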

Compound 3, percent growth inhibition at one concentration: 22.9%
Beside the measured number, compound 3's estimate is 13.9 percentage points below it, and the stated range ends below it.
By their numbers in this assay, from the lowest: compounds 1 and 2 (each within the scatter of the next); then compound 3.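

In this assay the group on the sulfur now makes a difference beyond the scatter, with a number 12.6 percentage points higher from compound 2 to compound 3 (beyond the scatter) for 4-methylphenyl in place of 5-(trifluoromethyl)pyridin-2-yl and a number 16.2 percentage points higher from compound 1 to compound 3 (beyond the scatter) for 4-methylphenyl in place of 3-fluorophenyl. This position is therefore not indifferent to what sits on it, and compound 3 stands apart from both other compounds, although both steps are modest. No measurement at hand explains this gain.

Going by these compounds, compound 3 is the only one of the three with a methyl group and the only one without fluorine, so it remains open which of these differences goes with the higher number. A plain phenyl, a 4-ethylphenyl or a 4-methoxyphenyl on the sulfur would help to separate the two.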